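Propyl to Cyclohexyl on the Amide-Type Ring Nitrogen

A few compounds are considered here, and "the series" means these few. Any claim that something is new, unique, unknown or untested is made for them only; others in the source may bear on it.

Compound 3 `CCCN1Cc2cc(OCc3cccc(-c4ccc(Cl)c(C(=O)O)c4)c3)ccc2C1=O` has no number to stand on: in an assay on HEK293 cells for positive allosteric modulation of metabotropic glutamate receptor 2 (Rattus norvegicus), read by thallium flux (on this read-out higher numbers stand for larger maximal responses and lower numbers for smaller maximal responses), compound 3 is recorded as "not determined" (no result reported). For the measured compounds named here, the only measured step at this position runs from compound 1 `O=C(O)c1cc(-c2cccc(COc3ccc4c(c3)CN(CC3CC3)C4=O)c2)ccc1Cl`, which in this assay gives 85.7%, to compound 2 `CC(C)CN1Cc2cc(OCc3cccc(-c4ccc(Cl)c(C(=O)O)c4)c3)ccc2C1=O`, which gives 63.9%; that change of substituent on the saturated chain carbon lowered the maximal response, a number 21.8 percentage points lower from compound 1 to compound 2 (beyond the scatter). Compound 4 `O=C(O)c1cc(-c2cccc(COc3ccc4c(c3)CN(C3CCCCC3)C4=O)c2)ccc1Cl` differs from compound 3 by cyclohexyl in place of propyl on an amide-type nitrogen in a ring. Going by the values given here, since compound 3 has no value and the one measured step concerns a different change, the expectation for compound 4 is loose; its maximal response in this assay is estimated at 70%, expected to fall between 45% and 95%.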

Compound 4, largest response reached (Emax), in percent of the reference or control that the assay uses: 63.3%
The estimate for compound 4 lay 6.7 percentage points above the measured number, within the range that was stated.
By their numbers in this assay, from the lowest: compounds 4 and 2 (each within the scatter of the next); then compound 1.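

In this assay the amide-type nitrogen in a ring now carries three measured groups. Cyclohexyl and isobutyl cannot be told apart (a number 0.6 percentage points lower from compound 2 to compound 4 (within the scatter)), while cyclopropylmethyl stands clear of cyclohexyl (a number 22.4 percentage points lower from compound 1 to compound 4 (beyond the scatter)), so the lower response is not confined to isobutyl. Nothing available explains these numbers. Compound 3 has no number, so the step from propyl to cyclohexyl cannot be read. From the compounds shown here alone, whether a longer chain, or a chain bearing an amine or a carboxylic acid, on this nitrogen would match compound 1 remains open.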